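Hydroxy in Place of Fluoro: From Compound 2 to Compound 3

The source may report more compounds than this note shows. Statements on the series, on what has been measured and on what is new or still open speak of the compounds shown alone.

Compound 1, `O=C(/C=C\Nc1ccc(F)cc1)c1cn(-c2ccccc2)nc1-c1ccc(Cl)cc1`: > 50000 nM, a limit of the assay
Compound 2, `COc1cc(-c2nn(-c3ccccc3)cc2C(=O)/C=C\Nc2ccc(F)cc2)cc(OC)c1OC`: 25700 nM

Of the two compounds measured in an ADME assay on HaCaT cells (Homo sapiens) for antiproliferative activity, read by MTT assay, with a stated time of 48 h (a lower number here means a stronger inhibitor, a higher number a weaker inhibitor), only compound 2 carries a number, and in this assay compound 2 gives 25700 nM. For the measured compounds named here, compound 1 stands at the limit of > 50000 nM in this assay, at which 1 of the 2 values shown sits, so no step between the two measured compounds can be sized.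

Compound 3, `COc1cc(-c2nn(-c3ccccc3)cc2C(=O)/C=C\Nc2ccc(O)cc2)cc(OC)c1OC`, differs from compound 2 by hydroxy in place of fluoro on an aromatic carbon. Going by the values given here, no pair of measured compounds shows this change, so its effect is unknown here; the expected step in this assay is small, not clearly beyond the usual scatter, in either direction. Compound 3 is therefore expected near 22000 nM, between 7000 nM and 60000 nM, which amounts to an expected step of a 1.2-fold lower number from compound 2 to compound 3 (0.07 log units; within the scatter).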

Compound 3, half-maximal inhibitory concentration: 17600 nM
The estimate for compound 3 lay 1.3-fold (0.10 log units) above the measured number; measured number inside the range.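

For the compounds shown here, the first step that can be sized in this assay is a 1.5-fold lower number from compound 2 to compound 3 (0.16 log units; within the scatter), for hydroxy in place of fluoro on the aromatic carbon para to a large group. At this position, then, hydroxy brings a hydrogen-bond donor and a hydrogen-bond acceptor that fluoro does not have, yet compound 2 and compound 3 cannot be told apart in this read-out. Nothing shown here bears on the reason for this outcome.

On these data alone, whether an amine or a carboxylic acid at the same position would carry the number beyond the scatter remains open. As far as these compounds go, compound 1 gives > 50000 nM, a limit of the assay, so whether the same exchange would read alike on the core of compound 1 also remains open.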